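The compounds below may be only part of what the source reports. "The series", "measured", "known", "first", "only" and "open" are said of these compounds alone.

The measured compounds share one core and differ in the group on its carbonyl carbon. In an ADME assay on MRC5 cells (Homo sapiens) for inhibition, with a stated time of 72 h (a higher number here means that more compound is needed for the effect, a lower number that less compound is needed), compound 1 `COc1cccc(OC)c1C(=O)Nc1c[nH]nc1C(=O)N[C@H]1CC[C@H](O)CC1` gives 34000 nM as its half-maximal effective concentration. Compound 2 `COc1cccc(OC)c1C(=O)Nc1c[nH]nc1C(=O)O` gives > 50000 nM and this is a limit of the assay, not a number. Compound 3 `CCCCCNC(=O)c1n[nH]cc1NC(=O)c1c(OC)cccc1OC` gives > 50000 nM and this too is a limit, so compound 3 has no exact value. The picture is framed by the limit of > 50000 nM in this assay, at which 2 of the 3 values shown sit, and only compound 1 has a true number.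

Compound 4 `COc1cccc(OC)c1C(=O)Nc1c[nH]nc1C(=O)NC1CCC(C)CC1` keeps the core of compound 3 but carries 4-methylcyclohexyl in place of pentyl on an amide-type nitrogen. The nearest evidence is the change on that same nitrogen with pentyl in place of 4-hydroxycyclohexyl (an at least 1.4-fold higher number from compound 1 to compound 3 (0.16 log units; that floor lies within the scatter)) and its floor lies within the scatter. The other step that reaches compound 3 (a step that the two limits leave unreadable from compound 2 to compound 3) cannot be read and adds no size. Compound 4 has a ring on that nitrogen, as compound 1 does, so a slightly lower number is possible, though it may also return only a limit. The expected step (an at least 1.2-fold lower number from compound 3 to compound 4 (0.09 log units; that floor lies within the scatter)) is small and not clearly beyond the scatter. In this assay the estimate for compound 4 is 40000 nM (expected range 15000 nM to 70000 nM) for now.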

Compound 4, half-maximal effective concentration: 45000 nM
The estimate for compound 4 lay 1.1-fold (0.05 log units) below the measured number, within the range that was stated.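

Compound 4 adds a second true number in this assay, so two rings on the amide-type nitrogen can now be compared directly instead of through a limit. Putting 4-methylcyclohexyl in place of 4-hydroxycyclohexyl gives a 1.3-fold higher number from compound 1 to compound 4 (0.12 log units; within the scatter), so in this pair the exchange of the two ring groups produces no difference that can be told from scatter. Compared with the pentyl chain and with the hydroxy on the carbonyl carbon, the readings are an at least 1.1-fold lower number from compound 3 to compound 4 (0.04 log units; that floor lies within the scatter) and an at least 1.1-fold lower number from compound 2 to compound 4 (0.04 log units; that floor lies within the scatter); both are only floors, so neither shows that the ring itself makes a real difference, and the one remaining step, from compound 2 to compound 3, cannot be read.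

Going by these compounds, what a ring carrying an amine, or a chain longer than pentyl, would give on this nitrogen stays open, as does whether any group there can bring the number clearly down. The true size of the steps that end at a limit also stays open, and limits still mark the upper edge of what can be read in this assay: the limit of > 50000 nM in this assay, at which 2 of the 4 values shown sit.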